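Methyl on the Sulfonyl Aryl Ring of a Proline Anilide

A few compounds are considered here, and "the series" means these few. Any claim that something is new, unique, unknown or untested is made for them only; others in the source may bear on it.

Compound 1 `Cc1ccc(S(=O)(=O)N2CC(O)C[C@H]2C(=O)Nc2ccc(C(=O)O)cc2)cc1`: 58%
Compound 2 `O=C(O)c1ccc(NC(=O)[C@@H]2CCCN2S(=O)(=O)c2ccccc2)cc1`: 23.6%

Of the compounds shown here, two have been tested in a functional assay on the whole organism for inhibition, with Rattus norvegicus as the target, read by paw edema, with stated times of 1 h and 0.5 h, at a dose of 100 mg/kg by the oral route; on this read-out higher numbers stand for more inhibition at the one dose given (going by the name of the read-out) and lower numbers for less inhibition. Compound 1 stands higher, and compound 2, at 23.6%, has the lowest number of the pair; the gap between them lies beyond the scatter. Going by the values given here, compound 1 and compound 2 differ in more than one place, so their two values show only that a combined change is associated with this gap.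

Compound 3 `Cc1ccc(S(=O)(=O)N2CCC[C@H]2C(=O)Nc2ccc(C(=O)O)cc2)cc1` has not yet been measured. It differs from compound 2 in one way: methyl in place of hydrogen on an aromatic carbon; cut one bond further out, the change reads phenyl to 4-methylphenyl, on an aromatic carbon para to a large group.

Among the compounds with values here, no single-change step is known here. An increase of moderate size is expected, because compound 1, which also carries this methyl, reaches 58%. The step of a number 14.4 percentage points higher from compound 2 to compound 3 (beyond the scatter) is the estimated outcome. Compound 3 is expected to give 38%, in a range from 18% to 58%.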

Compound 3, a percentage reported as inhibition, in the whole organism at one dose (the size of the read-out at that dose, not a potency): 28.8%
Estimate against measurement, compound 3: 9.2 percentage points above, and the stated range covers the measured number.
By their numbers in this assay, from the lowest: compounds 2 and 3 (each within the scatter of the next); then compound 1.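

In this assay, methyl in place of hydrogen on an aromatic carbon, para to a large group, gives a number 5.2 percentage points higher from compound 2 to compound 3 (within the scatter), so the change from phenyl to 4-methylphenyl does not separate these two compounds. The same compound also isolates a second single change: hydrogen in place of hydroxy on a saturated ring carbon gives a number 29.2 percentage points lower from compound 1 to compound 3 (beyond the scatter), making this the only one of the two single changes that moves the number beyond the scatter. No measurement shown here bears on the reason for either step.

As far as these compounds go, whether the methyl would matter with the hydroxy present remains open. So does whether an amine or a methoxy group on that saturated ring carbon would keep the number of compound 1.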